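Removing the Ethoxycarbonyl from a Fused Dione Core

The compounds below may be only part of what the source reports. "The series", "measured", "known", "first", "only" and "open" are said of these compounds alone.

Measured in a functional assay with Rattus norvegicus as the target; a lower number here means a stronger inhibitor, a higher number a weaker inhibitor:
compound 1 `O=C(O)c1ccc2[nH]c(=O)c(=O)oc2c1` gives 16000 nM
compound 2 `COc1ccc2oc(=O)c(=O)[nH]c2c1` gives 15000 nM
compound 3 `CCOC(=O)c1ccc2oc(=O)c(=O)[nH]c2c1` gives 10000 nM

All three numbers in this assay lie within the scatter of one another, so compound 3 does not separate from compound 1 or compound 2. The only single-site step shown, a 1.5-fold lower number from compound 2 to compound 3 (0.18 log units; within the scatter), is itself within the scatter. Compound 4 `O=c1[nH]c2ccccc2oc1=O` differs from compound 3 by hydrogen in place of ethoxycarbonyl on an aromatic carbon. No measured step removes a substituent entirely, so the bearing of the shown data is indirect; the substituent variation seen so far moved nothing beyond the scatter. Compound 4 is therefore expected to land near compound 3, with a step of a 1.4-fold higher number from compound 3 to compound 4 (0.15 log units; within the scatter) that stays inside the scatter. The estimate for compound 4 in this assay is 14000 nM, ranging from 6000 nM to 35000 nM.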

Compound 4, half-maximal inhibitory concentration: 42000 nM
Compound 4: the middle estimate sits 3.0-fold (0.48 log units) below what was measured; the measured number lies above the stated range.
By their numbers in this assay, from the lowest: compounds 3, 2 and 1 (each within the scatter of the next); then compound 4.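

In this assay, hydrogen on this aromatic carbon separates compound 4 from every substituted compound: the steps (a 4.2-fold higher number from compound 3 to compound 4 (0.62 log units; beyond the scatter)), (a 2.8-fold higher number from compound 2 to compound 4 (0.45 log units; beyond the scatter)) and (a 2.6-fold higher number from compound 1 to compound 4 (0.42 log units; beyond the scatter)) all lie beyond the scatter, whereas compounds 1, 2 and 3 stay within the scatter of one another. Among these four compounds, then, having any of the three groups matters more than which one it is, and compound 4 is the weakest inhibitor. No evidence accounts for this difference.

The compounds shown leave open whether a group as small as methyl or fluorine would already give the lower number. They also leave open how an amine or a longer ester chain would behave here.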